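Amide aryl variation on the shared core

The source may report more compounds than this note shows. Statements on the series, on what has been measured and on what is new or still open speak of the compounds shown alone.

Measured so far:
- compound 1 `COc1cc(N(C)CCN(C)C)c(NC(=O)c2ccnc(O)c2)cc1Nc1nccc(-c2cn(C)c3ccccc23)n1`: 12000 nM in a functional assay on NCI-H1975 cells (Homo sapiens) for antiproliferative activity, read by MTT assay, with a stated time of 72 h; on this read-out lower numbers stand for stronger inhibition and higher numbers for weaker inhibition
- compound 2 `COc1cc(N(C)CCN(C)C)c(NC(=O)c2ccncc2OC)cc1Nc1nccc(-c2cn(C)c3ccccc23)n1`: 1010 nM in this assay

Compound 2 gives the lowest number of the two; its nearest neighbour is compound 1, the step being a 12-fold lower number from compound 1 to compound 2 (1.07 log units; beyond the scatter). Compound 3 `COc1cc(N(C)CCN(C)C)c(NC(=O)c2cccnc2)cc1Nc1nccc(-c2cn(C)c3ccccc23)n1` differs from compound 2 by pyridin-3-yl in place of 3-methoxypyridin-4-yl on a carbonyl carbon. Among the compounds with values here, the only measured step, a 12-fold lower number from compound 1 to compound 2 (1.07 log units; beyond the scatter), changes a substituent on the same ring but does not remove the methoxy or shift the ring nitrogen, so it bears on this step only loosely. A modest rise in number is expected, a 2.0-fold higher number from compound 2 to compound 3 (0.30 log units; within the scatter). For compound 3 the estimate in this assay is 2000 nM, range 500 nM to 8000 nM.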

Compound 3, half-maximal inhibitory concentration: 1750 nM
Estimate against measurement, compound 3: 1.1-fold (0.06 log units) above, and the stated range covers the measured number.
By their numbers in this assay, from the lowest: compounds 2 and 3 (each within the scatter of the next); then compound 1.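

In this assay, exchanging 3-methoxypyridin-4-yl for pyridin-3-yl on this carbonyl carbon gives no separation (a 1.7-fold higher number from compound 2 to compound 3 (0.24 log units; within the scatter)), so a pyridine ring without the methoxy group still reads alongside compound 2. Compound 1 alone stands apart, as pyridin-3-yl in place of 2-hydroxypyridin-4-yl also gives a clear step (a 6.9-fold lower number from compound 1 to compound 3 (0.84 log units; beyond the scatter)). No measurement on hand accounts for either step.

The step from 3-methoxypyridin-4-yl to pyridin-3-yl removes the methoxy and changes the pyridine attachment together, so the two changes cannot be read apart. From the compounds shown here alone, a plain phenyl, unsubstituted pyridin-4-yl or an amine on the ring remains open at this position.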